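Relocating the Methoxy Group on a Sulfonate Series

The source may report more compounds than this note shows. Statements on the series, on what has been measured and on what is new or still open speak of the compounds shown alone.

Measured compounds:
compound 1 `CCCN1CCN(c2ccc(S(=O)(=O)Oc3cccc(OC)c3)cc2)C1=O` — in a functional assay on MCF7 cells (Homo sapiens) for antiproliferative activity, read by sulforhodamine B assay, with a stated time of 48 h (on this read-out lower numbers stand for stronger inhibition and higher numbers for weaker inhibition), compound 1 gives 6300 nM
compound 2 `CCCCN1CCN(c2ccc(S(=O)(=O)Oc3cccc(OC)c3)cc2)C1=O` — in this assay compound 2 gives 490 nM

Compound 2 holds the lower of the two numbers recorded in this assay. Among the measured compounds shown here, the one measured step, a 13-fold lower number from compound 1 to compound 2 (1.11 log units; beyond the scatter), is large and concerns only the chain on the ring nitrogen.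

Compound 3 `CCCCN1CCN(c2ccc(S(=O)(=O)Oc3ccc(OC)cc3)cc2)C1=O` differs from compound 2 in a single place: 4-methoxyphenyl in place of 3-methoxyphenyl on an oxygen. For the measured compounds named here, no measured step bears on a change of this kind; the recorded step says nothing about the methoxyphenyl part of the molecule. Without a guide from the measured pair, the step from compound 2 to compound 3 is expected to stay within the scatter, in either direction: a 1.2-fold higher number from compound 2 to compound 3 (0.09 log units; within the scatter). Compound 3 is therefore estimated at 600 nM in this assay, with a range from 150 nM to 2500 nM.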

Compound 3, half-maximal inhibitory concentration: 2500 nM
For compound 3 the middle estimate is 4.2-fold (0.62 log units) below the measured one, and the stated range covers the measured number.
By their numbers in this assay, from the lowest: compound 2; then compound 3; then compound 1.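

The methoxy group's location on the aryl ring matters in this assay, a point the earlier pair, which differed only in the chain on the ring nitrogen, could not show. With the rest of the molecule unchanged, replacing 3-methoxyphenyl with 4-methoxyphenyl on the oxygen gives a 5.1-fold higher number from compound 2 to compound 3 (0.71 log units; beyond the scatter) even though the two groups have the same atoms. This part of the molecule therefore affects the number in this assay, with 3-methoxyphenyl giving the lower value of the two, but no available evidence explains the difference.

As far as these compounds go, it remains open whether an ethoxy group, a hydroxyl group or a fluorine in place of the methoxy group would give a lower or higher number. From the compounds shown here alone, it is also open whether 3-methoxyphenyl would still give the lower number when paired with the shorter chain of compound 1.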